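Quinoline carboxylic acids: ethoxy in place of fluoro

The compounds below may be only part of what the source reports. "The series", "measured", "known", "first", "only" and "open" are said of these compounds alone.

Measured so far:
compound 1 `O=C(O)c1cnc2c(Cl)cccc2c1`, 25 mg/kg
compound 2 `O=C(O)c1cnc2c(F)cccc2c1`, > 25 mg/kg

Compound 2 stands at a limit of the assay, > 25 mg/kg in a functional assay on the whole organism (strain Sprague-Dawley) for inhibition, with Rattus norvegicus as the target (on this read-out higher numbers stand for an effect only at larger amounts of compound and lower numbers for an effect already at smaller amounts), not at a number (the limit of > 25 mg/kg in this assay, at which 1 of the 2 values shown sits). Compound 3 `CCOc1cccc2cc(C(=O)O)cnc12` carries the change (ethoxy in place of fluoro on an aromatic carbon). Going by the values given here, the only measured step, a number no lower from compound 1 to compound 2 (the limit leaves the size open), concerns a different exchange and its size is not readable, so no step beyond the scatter can be expected for this assay in either direction. Compound 3 is therefore estimated at 25 mg/kg (range 10 mg/kg to 60 mg/kg), an expected step of a number no higher from compound 2 to compound 3 (the limit leaves the size open).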

Compound 3, minimum effective dose: > 25 mg/kg
Compound 3 was reported as a limit; the forecaster's own chance of this, stated with the estimate: 50%; the middle value sits exactly at the limit.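

In this assay compound 3 gives > 25 mg/kg, which is a limit and not a number. Ethoxy in place of chloro on this aromatic carbon gives a number no lower from compound 1 to compound 3 (the limit leaves the size open), and the step between compound 2 and compound 3 cannot be read. Ethoxy thus joins fluoro at the limit, leaving compound 1 as the only compound with a number: the limit of > 25 mg/kg in this assay, at which 2 of the 3 values shown sit.

On these data alone, how an amine or a methoxy on this aromatic carbon would read against compound 1 stays open. So does the reading of a longer chain such as butoxy.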